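Swapping a saturated ring for a pyrazole on compound 3

The source may report more compounds than this note shows. Statements on the series, on what has been measured and on what is new or still open speak of the compounds shown alone.

Of the compounds shown here, three that share one core have been tested in an assay on HT-29 cells for inhibition of Serine-protein kinase ATM (Homo sapiens), read by fluorescence, with a stated time of 1 h; a higher number here means a weaker inhibitor, a lower number a stronger inhibitor. Compound 1 `COCc1ccc(-c2ccc3nnc(C(N)=O)c(N[C@@H](C)C4CCOCC4)c3c2)cn1` gives 140 nM in this assay. Compound 2 `COCc1ccc(-c2ccc3nnc(C(N)=O)c(N[C@@H](C)c4ccn(C)n4)c3c2)cn1` gives 260 nM. Compound 3 `C[C@H](Nc1c(C(N)=O)nnc2ccc(-c3ccc(OCCCN(C)C)nc3)cc12)C1CCOCC1` gives 1.9 nM and stands as the lowest of the three numbers; the gap to the nearest, compound 1, is beyond the scatter, and so is the gap to compound 2. Two single changes connect these values: a 1.9-fold higher number from compound 1 to compound 2 (0.27 log units; within the scatter), and a 74-fold lower number from compound 1 to compound 3 (1.87 log units; beyond the scatter).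

Compound 4 `Cc1cn(C)nc1[C@H](C)Nc1c(C(N)=O)nnc2ccc(-c3ccc(OCCCN(C)C)nc3)cc12` has not yet been measured. It differs from compound 3 in one place: 1,4-dimethyl-1H-pyrazol-3-yl in place of oxan-4-yl on a saturated chain carbon bound to a nitrogen on an aromatic ring and a saturated chain carbon. Within the data shown here, the closest precedent is the step from compound 1 to compound 2, which put a 1-methyl-1H-pyrazol-3-yl in place of the same oxan-4-yl at the same place and stayed within the scatter; the ring entering here carries one extra methyl, so it is not an identical change. On that basis the step is expected to be small, a 1.8-fold higher number from compound 3 to compound 4 (0.27 log units; within the scatter), and compound 4 is estimated to give 3.5 nM, likely between 1.5 nM and 9 nM.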

Compound 4, half-maximal inhibitory concentration: 0.9 nM
The estimate for compound 4 lay 3.9-fold (0.59 log units) above the measured number, outside the stated range (below it).
By their numbers in this assay, from the lowest: compound 4; then compound 3; then compounds 1 and 2 (each within the scatter of the next).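

The replacement of oxan-4-yl by 1,4-dimethyl-1H-pyrazol-3-yl, with 3-(dimethylamino)propoxy on the aromatic carbon, gives a 2.1-fold lower number from compound 3 to compound 4 (0.32 log units; beyond the scatter) in this assay and so a modest gain, beyond the scatter. This shows that an aromatic five-membered ring can improve on the saturated ring at this place, something the earlier pair could not show, since a 1.9-fold higher number from compound 1 to compound 2 (0.27 log units; within the scatter) stayed within the scatter with a pyrazole lacking the extra methyl and with methoxymethyl on the aromatic carbon. No measurement is available to explain this gain.

The compounds shown cannot separate the effect of the extra methyl from that of the 3-(dimethylamino)propoxy group, since these two steps differ in both. From the compounds shown here alone, how an ethyl group in place of that extra methyl, or an open-chain ether in place of the ring, would read also remains open.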